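Lengthening the ester chain in a series of quinazoline-type amides

This account rests on a few compounds, and the source may have more. Where it says the series, first, only, none or still open, it means among the compounds named here.

Three compounds share one core and differ only in the ester chain at one end. Compound 1 `CCCOC(=O)CCC(=O)N1CCN(CCCOc2cc3c(Nc4ccc(F)c(Cl)c4)ncnc3cc2OC)CC1` carries a propyl ester, compound 2 `CCCCOC(=O)CCC(=O)N1CCN(CCCOc2cc3c(Nc4ccc(F)c(Cl)c4)ncnc3cc2OC)CC1` a butyl ester, and compound 3 `CCCCCCCCCCCCCCCCCCOC(=O)CCC(=O)N1CCN(CCCOc2cc3c(Nc4ccc(F)c(Cl)c4)ncnc3cc2OC)CC1` a long-chain ester, as its structure shows. In a functional assay on A549 cells (Homo sapiens) for cytotoxicity, read by MTT assay, with a stated time of 24 h, tested at 60 uM (a lower number here means a stronger effect, a higher number a weaker effect of the compound at the concentration tested), compound 1 gives 70.4% and compound 2 gives 64.1%; the change between them is methyl in place of hydrogen on a saturated chain carbon, three bonds along the chain from an oxygen next to a carbonyl group and the step is a number 6.3 percentage points lower from compound 1 to compound 2 (within the scatter). Compound 3 gives 87.2%, the highest of the three, and the difference between its core and that of compound 1 is not broken down here.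

Compound 4 `CCCCCCCCCCCCCCCCCCCOC(=O)CCC(=O)N1CCN(CCCOc2cc3c(Nc4ccc(F)c(Cl)c4)ncnc3cc2OC)CC1` has not yet been measured. It differs from compound 3 by methyl in place of hydrogen on a saturated chain carbon, ten or more bonds along the chain from an oxygen next to a carbonyl group. This is the same kind of change as that from compound 1 to compound 2, but not the same: the added methyl sits at a different place along the chain in each case, as the two differences state. Because the earlier step of a number 6.3 percentage points lower from compound 1 to compound 2 (within the scatter) stayed within the scatter, a similarly small step is expected here, estimated as a number 1.2 percentage points lower from compound 3 to compound 4 (within the scatter). Compound 4 is therefore expected to give about 86%, with a likely range from 74% to 97%.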

Compound 4, a percentage reported as activity, at one concentration (the size of the read-out at that concentration, not a potency): 89.3%
Beside the measured number, compound 4's estimate is 3.3 percentage points below it, within the range that was stated.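

In this assay, adding the methyl to the long chain gives a small step, a number 2.1 percentage points higher from compound 3 to compound 4 (within the scatter). Set beside the same kind of change on the shorter chain, the two steps cannot be told apart: the same change on two cores in this assay, a number 6.3 percentage points lower (within the scatter) from compound 1 to compound 2 and a number 2.1 percentage points higher (within the scatter) from compound 3 to compound 4, 8.4 percentage points apart, within the scatter of two such steps. Within these two pairs, then, the change carries from the core of compound 1 to the core of compound 3 with no clear difference in the read-out, but this rests on only two pairs at one tested concentration, with the methyl at a different place along the chain in each, and it does not show that the step would stay small on another core or at another place on the chain.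

The compounds shown leave open how an ester chain of middling length, such as octyl or dodecyl, would read in this assay. They also leave open what a free carboxylic acid or a benzyl ester would give in place of these straight-chain esters.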